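A few compounds are considered here, and "the series" means these few. Any claim that something is new, unique, unknown or untested is made for them only; others in the source may bear on it.

Of the compounds shown here, three of one shared core have been measured in a functional assay on CCRF-CEM cells (Homo sapiens) for cytotoxicity, read by MTT assay, with a stated time of 72 h; on this read-out lower numbers stand for stronger inhibition of growth and higher numbers for weaker inhibition of growth. Compound 1, `C[Se]c1nc(N)c2ccccc2n1`, gives only a limit of the assay, > 100000 nM. Compound 2, `CCCCC[Se]c1nc([Se]CCCCC)c2ccccc2n1`, likewise gives only a limit, > 100000 nM. Compound 3, `Nc1nc([SeH])nc2ccccc12`, gives 52400 nM, and it is the only number shown. For the measured compounds named here, the one measured step runs from compound 1 to compound 3 and amounts to an at least 1.9-fold lower number from compound 1 to compound 3 (0.28 log units; that floor lies within the scatter); the relevant evidence is the limit of > 100000 nM in this assay, at which 2 of the 3 values shown sit.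

Compound 4 is `CCCCC[Se]c1nc(N)c2ccccc2n1`. It differs from compound 3 by pentyl in place of hydrogen on a selenium. The step from compound 1 to compound 3 replaced an alkyl group on the selenium by hydrogen and gave a lower number only at a floor inside the scatter, so putting a pentyl group back on that selenium runs in the opposite direction and is expected to give a higher number, quite possibly back to a limit. The step from compound 3 to compound 4 is therefore estimated at a 1.9-fold higher number from compound 3 to compound 4 (0.28 log units; within the scatter). Compound 4 is expected to give 100000 nM, in the range 40000 nM to 300000 nM.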

Compound 4, concentration for total growth inhibition: 68000 nM
Beside the measured number, compound 4's estimate is 1.5-fold (0.17 log units) above it; the measured number falls inside the stated range.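

In this assay, for the compounds shown here, pentyl in place of hydrogen on a selenium is the first change here that can be read between two actual numbers, and a 1.3-fold higher number from compound 3 to compound 4 (0.11 log units; within the scatter) shows that a pentyl chain on this selenium does not by itself take the number to a limit of the assay. Butyl in place of hydrogen on the saturated chain carbon bound to the selenium gives an at least 1.4-fold lower number from compound 1 to compound 4 (0.16 log units; that floor lies within the scatter), and one nitrogen atom in place of the group of 6 heavy atoms on an aromatic carbon gives an at least 1.4-fold lower number from compound 2 to compound 4 (0.16 log units; that floor lies within the scatter). Both steps are floors, so neither has a readable size: the limit of > 100000 nM in this assay, at which 2 of the 4 values shown sit.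

As far as these compounds go, what remains open is whether any group on this selenium can move the number beyond the scatter. A longer chain, or a chain ending in an amine or a carboxylic acid, could test this.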